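The compounds below may be only part of what the source reports. "The series", "measured", "known", "first", "only" and "open" are said of these compounds alone.

Measured so far, in a functional assay on A549 cells (Homo sapiens) for antiproliferative activity, read by MTT assay, with a stated time of 72 h; a lower number here means a stronger inhibitor, a higher number a weaker inhibitor:

- compound 1 `COc1cc(F)c(NC(=O)c2ccncc2)cc1Nc1nccc(-c2cn(C)c3ccccc23)n1`: compound 1 gives 4200 nM
- compound 2 `COc1cc(F)c(NC(=O)c2nccn2C)cc1Nc1nccc(-c2cn(C)c3ccccc23)n1`: compound 2 gives 5140 nM
- compound 3 `COc1cc(N(C)CCN(C)C)c(NC(=O)c2ccncc2)cc1Nc1nccc(-c2cn(C)c3ccccc23)n1`: compound 3 gives 10400 nM

Compound 3 carries the highest number of the three, which in this assay means the weakest inhibitor of cell growth. Its distance to compound 1 is the step of a 2.5-fold higher number from compound 1 to compound 3 (0.39 log units; beyond the scatter), and compound 2 sits a little closer to it than compound 1 does.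

Compound 4 `COc1cc(N(C)CCN(C)C)c(NC(=O)c2ccncn2)cc1Nc1nccc(-c2cn(C)c3ccccc23)n1` keeps everything in compound 3 except the ring attached to the carbonyl carbon: pyrimidin-4-yl in place of pyridin-4-yl on a carbonyl carbon. Going by the values given here, only one measured step touches that same spot, the exchange of the pyridin-4-yl ring for a different small aromatic ring between compounds 1 and 2, which gave a 1.2-fold higher number from compound 1 to compound 2 (0.09 log units; within the scatter). That step stayed within the scatter, and nothing else among the three compounds bears on the carbonyl ring. The exchange from compound 3 to compound 4 is therefore expected to give a step of about no change at the digits printed from compound 3 to compound 4 (within the scatter), that is, no change beyond the scatter, in either direction. On that basis compound 4 is expected to give about 10400 nM in this assay, with a likely range from 4500 nM to 24000 nM.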

Compound 4, half-maximal inhibitory concentration: 2530 nM
The estimate for compound 4 lay 4.1-fold (0.61 log units) above the measured number; the measured number lies below the stated range.
By their numbers in this assay, from the lowest: compounds 4, 1 and 2 (each within the scatter of the next, the first and the last beyond it); then compound 3.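

In this assay, the carbonyl ring turns out to be a place where a small exchange can count: replacing pyridin-4-yl with pyrimidin-4-yl, which keeps the six heavy atoms of the ring and changes one ring carbon to nitrogen, gives a 4.1-fold lower number from compound 3 to compound 4 (0.61 log units; beyond the scatter) and goes beyond the usual scatter. Going by these compounds alone, the only earlier change at this spot, a 1.2-fold higher number from compound 1 to compound 2 (0.09 log units; within the scatter), stayed within the scatter and could have suggested that the ring there matters little, but that was a different ring exchange on a core carrying fluoro rather than the (2-(dimethylamino)ethyl)(methyl)amino group. No measurement available here accounts for the effect of the added ring nitrogen or the added hydrogen-bond acceptor.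

The compounds shown leave open whether pyrimidin-4-yl would give a similar step on the fluoro-bearing core of compound 1, so the result cannot yet be called general. Going by these compounds, it is also open how a phenyl or pyrazin-2-yl ring on the same carbonyl carbon would compare with pyrimidin-4-yl on the core of compound 3.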